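Swapping the Aryl Group on the Amide-Type Nitrogen

The compounds below may be only part of what the source reports. "The series", "measured", "known", "first", "only" and "open" are said of these compounds alone.

Measured so far:
- compound 1 `O=C(Nc1ccc(Oc2ccc(-c3ncc[nH]3)cc2)cc1)Nc1ccc(Cl)c([N+](=O)[O-])c1`: 12.4%
- compound 2 `O=C(Nc1ccc(Oc2ccc(-c3ncc[nH]3)cc2)cc1)Nc1ccc(F)c(C(F)(F)F)c1`: 63.3%

In a functional assay on A549 cells (Homo sapiens) for inhibition, read by MTT assay and WST assay, with a stated time of 72 h, tested at 10 uM (on this read-out higher numbers stand for more inhibition of growth at the one concentration tested and lower numbers for less inhibition of growth), compound 2 gives 63.3%, the highest of the two numbers; its nearest neighbour is compound 1, which gives 12.4%. For the measured compounds named here, the one measured step, a number 50.9 percentage points higher from compound 1 to compound 2 (beyond the scatter), shows that exchanging the aryl group on the amide-type nitrogen moves the read-out strongly.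

Compound 3 `Cc1ccc(NC(=O)Nc2ccc(Oc3ccc(-c4ncc[nH]4)cc3)cc2)cc1` differs from compound 2 by 4-methylphenyl in place of 4-fluoro-3-(trifluoromethyl)phenyl on an amide-type nitrogen. Going by the values given here, no measured step covers this exact exchange. Among the compounds with values here, the only measured step bears on it indirectly: it shows that a change at this position can shift the number by a large amount. Given that compound 2 carries the group tied to the highest value, compound 3 is expected to fall back to a clearly lower number, estimated at 30% (range 10% to 55%), a step of a number 33.3 percentage points lower from compound 2 to compound 3 (beyond the scatter) beyond the scatter, though with wide uncertainty.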

Compound 3, percent growth inhibition at one concentration: 24.6%
Estimate against measurement, compound 3: 5.4 percentage points above; the range from low to high includes it.
By their numbers in this assay, from the lowest: compound 1; then compound 3; then compound 2.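

In this assay, the step of a number 38.7 percentage points lower from compound 2 to compound 3 (beyond the scatter) shows that the high number of compound 2 does not carry over to every aryl group on the amide-type nitrogen, as 4-methylphenyl loses much of it. The step of a number 12.2 percentage points higher from compound 1 to compound 3 (beyond the scatter) is modest but still beyond the scatter, so compound 3 stays in the lower part of the range while remaining separate from compound 1. Among these three compounds, only 4-fluoro-3-(trifluoromethyl)phenyl gives a high number, and nothing given here explains the differences between the groups.

From the compounds shown here alone, it remains open whether a 4-fluorophenyl or a 3-(trifluoromethyl)phenyl group would read closer to compound 2 or to compound 3. Going by these compounds, how an amine or a carboxylic acid on this aryl ring would read also remains open.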